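This account rests on a few compounds, and the source may have more. Where it says the series, first, only, none or still open, it means among the compounds named here.

Measured in a functional assay on K562 cells (Homo sapiens) for antiproliferative activity, read by MTT assay, with a stated time of 48 h (on this read-out lower numbers stand for stronger inhibition and higher numbers for weaker inhibition), so far
- compound 1 `CCCCc1ccc2c(c1)C(=O)C(=O)N2` gives > 10000 nM as a limit, not a number
- compound 2 `COc1ccc(CN2C(=O)C(=O)c3cc(-c4ccc(OC)cc4)ccc32)cc1` gives 30 nM
- compound 3 `COc1ccc(CN2C(=O)C(=O)c3cc(-c4cc(OC)cc(OC)c4)ccc32)cc1` gives 510 nM

Of the two true numbers, compound 3 holds the higher one at 510 nM and compound 2 holds the lower one at 30 nM in this series. Among the measured compounds shown here, compound 1 differs from the others in more than one place, so it supplies no step here.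

Next is compound 4 `COc1ccc(CN2C(=O)C(=O)c3cc(-c4ccc(F)cc4)ccc32)cc1` with the change 4-fluorophenyl in place of 3,5-dimethoxyphenyl on an aromatic carbon in which 4-fluorophenyl replaces 3,5-dimethoxyphenyl on an aromatic carbon. For the measured compounds named here, one measured step bears on this change: a 17-fold higher number from compound 2 to compound 3 (1.23 log units; beyond the scatter) when 3,5-dimethoxyphenyl replaced 4-methoxyphenyl at the same place. The entering 4-fluorophenyl is closer in pattern to the 4-methoxyphenyl of compound 2 than to the group it replaces. Going by the values given here, no measured compound carries fluorine, however, so only part of that step is expected to reverse. In this assay, among the compounds with values here, a move to a lower number, beyond the scatter, is therefore expected, resting on a 17-fold higher number from compound 2 to compound 3 (1.23 log units; beyond the scatter) as the sole guide. The expected move is a 4.3-fold lower number from compound 3 to compound 4 (0.63 log units; beyond the scatter) in this estimate. For compound 4 the estimated value is 120 nM with an expected range from 30 nM to 500 nM as the outer ends.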

Compound 4, half-maximal inhibitory concentration: 240 nM
Estimate against measurement, compound 4: 2.0-fold (0.30 log units) below; measured number inside the range.
By their numbers in this assay, from the lowest: compound 2; then compound 4; then compound 3. At a limit, above all of these: compound 1.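

In this assay, this aromatic carbon now has three aryl groups that can be compared directly, and 4-fluorophenyl gives a 2.1-fold lower number from compound 3 to compound 4 (0.33 log units; beyond the scatter) and sits apart from 4-methoxyphenyl with an 8.0-fold higher number from compound 2 to compound 4 (0.90 log units; beyond the scatter) on the same core. The earlier pair showed only that 3,5-dimethoxyphenyl carried a higher number than 4-methoxyphenyl, whereas these steps show that removing both methoxy groups of 3,5-dimethoxyphenyl and placing fluoro on the phenyl ring does not bring the series back to compound 2 at 30 nM in this assay. The low number therefore follows 4-methoxyphenyl among these three groups, and a single fluoro on the phenyl ring is not an equal replacement for methoxy in this series.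

Nothing measured here bears on why these three aryl groups fall in this order. On these data alone, it remains open whether an amine, a carboxylic acid or a longer alkoxy chain in place of the methoxy of 4-methoxyphenyl would hold the low number of compound 2 or move toward the higher number of compound 4.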